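This account rests on a few compounds, and the source may have more. Where it says the series, first, only, none or still open, it means among the compounds named here.

Measured so far in a functional assay on CHO cells for agonist activity at Alpha-1B adrenergic receptor (Homo sapiens), read by FLIPR and calcium flux; a higher number here means that more compound is needed for the effect, a lower number that less compound is needed:
Compound 1 `COc1c(C)ccc2c1CCC2c1ncc[nH]1` gives > 10000 nM, which is a limit of the assay rather than a number.
Compound 2 `c1cc(-c2ccn[nH]2)c2c(c1)C(c1ncc[nH]1)CC2` gives 600 nM.
Compound 3 `CCS(=O)(=O)Nc1cccc(Cc2c[nH]cn2)c1` gives > 10000 nM, again a limit of the assay and not a number.

Going by the values given here, compound 2 therefore holds the only actual number in this assay; the other two values sit at the limit of > 10000 nM in this assay, at which 2 of the 3 values shown sit. Compound 4 `Cc1oncc1-c1cccc2c1CCC2c1ncc[nH]1` differs from compound 2 in one place: 5-methyl-1,2-oxazol-4-yl in place of 1H-pyrazol-5-yl on an aromatic carbon. Among the compounds with values here, no pair of measured compounds shows this kind of change, so the size of the step cannot be read from the data. The exchange of a hydrogen-bond donor for a second acceptor is expected to cost some potency, with the step from compound 2 to compound 4 estimated as a 2.5-fold higher number from compound 2 to compound 4 (0.40 log units; beyond the scatter). Compound 4 is thus expected to give about 1500 nM, somewhere between 400 nM and 6000 nM.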

Compound 4, half-maximal effective concentration: > 10000 nM
Compound 4: a limit, no number (the forecaster's own chance of this, stated with the estimate: 20%); middle value at least 6.6-fold (0.82 log units) away from the limit.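

At this aromatic carbon, one five-membered aromatic ring cannot simply replace another: in this assay, 5-methyl-1,2-oxazol-4-yl in place of 1H-pyrazol-5-yl gives an at least 16-fold higher number from compound 2 to compound 4 (1.22 log units; beyond the scatter). The activity of compound 2 therefore depends on which group sits here, not merely on having such a ring at this place. The full size of the step stays unknown, as compound 4 carries a limit and not a number: the limit of > 10000 nM in this assay, at which 3 of the 4 values shown sit.

The change removes the hydrogen-bond donor and also adds a methyl, and these compounds cannot separate the two. From the compounds shown here alone, how an amine or a primary amide would fare at this carbon also stays open.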